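A few compounds are considered here, and "the series" means these few. Any claim that something is new, unique, unknown or untested is made for them only; others in the source may bear on it.

Of the compounds shown here, three have been measured so far in a functional assay on PC-3 cells (Homo sapiens) for inhibition, read by sulforhodamine B assay, with a stated time of 48 h (a lower number here means a stronger inhibitor of growth, a higher number a weaker inhibitor of growth), and all three sit close together. Compound 1, `COc1cc(C)cc(-c2c(-c3ccnc(-c4ccc(C(C)=O)cc4)c3)cnn2CC#N)c1`, gives 3590 nM in this assay. Compound 2, `COc1cc(C)cc(-c2nn(CC#N)cc2-c2ccc(-c3cccc(C(C)=O)c3)nc2)c1`, gives 3450 nM in this assay, and compound 3, `Cc1cc(O)cc(-c2nn(CC#N)cc2-c2ccnc(-c3ccc(N(C)C)cc3)c2)c1`, gives 3770 nM in this assay. Compound 1 stands second highest of the three numbers, but its nearest neighbour compound 2 and its furthest neighbour compound 3 both lie within the usual scatter of it, so no ordering among the three can be read from these figures.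

The next compound, compound 4, `COc1cc(C)cc(-c2c(-c3ccnc(-c4ccc(N(C)C)cc4)c3)cnn2CC#N)c1`, differs from compound 1 in one place: dimethylamino in place of acetyl on an aromatic carbon. Among the measured compounds shown here, no pair of measured compounds that differ in a single place is available, so the size of this step has to be judged from the compounds themselves. Compound 3 carries a dimethylamino group and gives 3770 nM, a number within the scatter of compound 1, so no step beyond the scatter is expected in this assay in either direction.

Compound 4 is therefore estimated to give 3700 nM in this assay, with a range from 1800 nM to 7500 nM. The expected step of a 1.0-fold higher number from compound 1 to compound 4 (0.01 log units; within the scatter) is essentially flat.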

Compound 4, concentration for 50% growth inhibition: 52.3 nM
Estimate against measurement, compound 4: 71-fold (1.85 log units) above; the whole stated range lies above it.
By their numbers in this assay, from the lowest: compound 4; then compounds 2, 1 and 3 (each within the scatter of the next).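

In this assay, the change from 4-acetylphenyl to 4-(dimethylamino)phenyl gives a 69-fold lower number from compound 1 to compound 4 (1.84 log units; beyond the scatter), a large step from a single change. The three earlier compounds lay within the scatter of one another, whereas this pair shows that the group on this aromatic carbon, para to a large group, can strongly shift the number, even though the leaving and entering groups match in heavy-atom count, hydrogen-bond donors and hydrogen-bond acceptors. No measurement shown here bears on the reason for a step of this size, so the pair records the change without explaining it.

The compounds shown leave open whether the step follows from adding the dimethylamino group or from removing the acetyl group, and how a primary amine or a morpholine would read at the same carbon. They also leave open whether the step carries over to other versions of the core, since compound 3 also bears dimethylamino but differs from compound 4 in more than one place and so cannot be compared with it.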